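Trifluoromethyl in place of (trifluoromethyl)sulfanyl: compound 3

A few compounds are considered here, and "the series" means these few. Any claim that something is new, unique, unknown or untested is made for them only; others in the source may bear on it.

Compound 1 `NS(=O)(=O)c1ccc2c(c1)C(=O)C(=O)N2Cc1cccc(C(F)(F)F)c1`: 6300 nM
Compound 2 `NS(=O)(=O)c1ccc2c(c1)C(=O)C(=O)N2Cc1ccc(SC(F)(F)F)cc1`: 6300 nM

In a functional assay on T47D cells (Homo sapiens) for inhibition, read by MTT assay, with a stated time of 72 h (a higher number here means a weaker inhibitor, a lower number a stronger inhibitor), compound 2 gives 6300 nM, which stands level with compound 1 at 6300 nM. Compound 3 `NS(=O)(=O)c1ccc2c(c1)C(=O)C(=O)N2Cc1ccc(C(F)(F)F)cc1` carries trifluoromethyl in place of (trifluoromethyl)sulfanyl on an aromatic carbon, para to a large group (trifluoromethyl in place of (trifluoromethyl)sulfanyl on an aromatic carbon). Among the measured compounds shown here, no measured pair isolates this change. Compound 1 also bears a trifluoromethyl group and gives 6300 nM, so little movement is expected in this assay. The estimated change, a 1.1-fold lower number from compound 2 to compound 3 (0.02 log units; within the scatter), is expected to stay within the scatter. For compound 3 the expected value is 6000 nM, with an estimated range of 2500 nM to 15000 nM.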

Compound 3, half-maximal inhibitory concentration: 22600 nM
Estimate against measurement, compound 3: 3.8-fold (0.58 log units) below, outside the stated range (above it).
By their numbers in this assay, from the lowest: compounds 1 and 2 (each within the scatter of the next); then compound 3.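

In this assay, this place on an aromatic carbon, para to a large group, responds to the exchange: trifluoromethyl in place of (trifluoromethyl)sulfanyl gives a 3.6-fold higher number from compound 2 to compound 3 (0.55 log units; beyond the scatter), a modest loss. Among the compounds shown here, the two groups are therefore not interchangeable here, which the level values of the earlier compounds could not show. No measurement given here accounts for this step.

On these data alone, whether the sulfur atom itself matters remains open, and a trifluoromethoxy or methylsulfanyl group at this place would help separate the contributions. As far as these compounds go, how an amine or a carboxylic acid would fare here also remains unknown.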